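Series notes: aryl ether to benzyl at the branched chain carbon

The compounds below may be only part of what the source reports. "The series", "measured", "known", "first", "only" and "open" are said of these compounds alone.

Three members of the series carry a value in an assay for inhibition of prostacyclin synthase (Homo sapiens), using microsomes; a higher number here means a weaker inhibitor, a lower number a stronger inhibitor. Compound 1 `CC(C)(Oc1ccc(F)cc1)C1OCC(C/C=C\CCC(=O)O)C(c2cccnc2)O1` gives 2000 nM. Compound 2 `CC(C)(Oc1ccccc1O)C1OCC(C/C=C\CCC(=O)O)C(c2cccnc2)O1` reaches only the limit of the assay, > 100000 nM, and no number is known for it; this is the case (the limit of > 100000 nM in this assay, at which 1 of the 3 values shown sits). Compound 3 `CC(C)(Oc1ccccc1Br)C1OCC(C/C=C\CCC(=O)O)C(c2cccnc2)O1` gives 7000 nM.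

Among the two numbers shown, compound 3 stands highest; its nearest neighbour is compound 1, with a 3.5-fold higher number from compound 1 to compound 3 (0.54 log units; beyond the scatter). The aromatic substituent weighs heavily here, as seen in an at least 50-fold higher number from compound 1 to compound 2 (1.69 log units; beyond the scatter) and in an at least 14-fold lower number from compound 2 to compound 3 (1.15 log units; beyond the scatter).

Compound 4 `CC(C)(Cc1ccc(F)cc1)C1OCC(C/C=C\CCC(=O)O)C(c2cccnc2)O1` differs from compound 3 by 4-fluorobenzyl in place of 2-bromophenoxy on a saturated chain carbon bound to two saturated chain carbons and a saturated ring carbon. Two parts of this change are separate. The return of the 4-fluoro substitution is covered by the measured step from compound 1 to compound 3, read in reverse, which points to a lower number for compound 4. Among the measured compounds shown here, the exchange of the ether oxygen for a methylene link has no measured counterpart, so its effect is open. The expected change is therefore a 2.8-fold lower number from compound 3 to compound 4 (0.45 log units; beyond the scatter), in the direction of compound 1. Compound 4 is estimated at 2500 nM, with a range from 600 nM to 12000 nM.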

Compound 4, half-maximal inhibitory concentration: 2000 nM
Beside the measured number, compound 4's estimate is 1.3-fold (0.10 log units) above it, within the range that was stated.
By their numbers in this assay, from the lowest: compounds 1 and 4 (each within the scatter of the next); then compound 3. At a limit, above all of these: compound 2.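

In this assay, among the compounds shown here, no change at the digits printed from compound 1 to compound 4 (within the scatter) isolates the link at this position for the first time: with the 4-fluorophenyl group held constant, the ether oxygen and the methylene cannot be told apart on this measure. Set against this, a 3.5-fold lower number from compound 3 to compound 4 (0.54 log units; beyond the scatter) is of the same size as a 3.5-fold higher number from compound 1 to compound 3 (0.54 log units; beyond the scatter), so the pair of compounds with the 4-fluoro substitution places the whole of that difference with the aromatic substitution and none of it with the link. The remaining step, an at least 50-fold lower number from compound 2 to compound 4 (1.69 log units; beyond the scatter), is a bound and not a measured size: the limit of > 100000 nM in this assay, at which 1 of the 4 values shown sits.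

For the compounds shown here, it remains open whether the link is equally interchangeable with a 2-bromo or 2-hydroxy substituent on the aromatic ring, as the only direct comparison of the two links carries the 4-fluoro substitution. Also open, as far as these compounds go, is how this position responds to a link of another kind, such as a thioether sulfur or an amine nitrogen, or to a longer chain between the saturated chain carbon and the aromatic ring.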